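The source may hold more compounds than are shown below. What is called first, only, known or untested is meant among the compounds shown, and "the series" means these compounds.

Measured compounds:
compound 1 `COc1cc2c(cc1OC)C(c1cccc(N)c1)=NN=C(S)C2` — 18.8 umol/kg
compound 2 `COc1cc2c(cc1OC)C(c1cccc([N+](=O)[O-])c1)=NNC(=O)C2` — > 120 umol/kg; for compound 2 this is a limit of the assay, not a number
compound 3 `COc1cc2c(cc1OC)C(c1ccc(N)cc1)=NN(C)C(=S)C2` — 29.8 umol/kg

In a functional assay on the whole organism with Mus musculus as the target (on this read-out higher numbers stand for an effect only at larger amounts of compound and lower numbers for an effect already at smaller amounts), compound 1 gives 18.8 umol/kg, the lower of the two numbers shown. Compound 3 gives 29.8 umol/kg, which lies within the scatter of compound 1, so no order between them is claimed. Compound 2 reaches only the limit described in the limit of > 120 umol/kg in this assay, at which 1 of the 3 values shown sits.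

Compound 4 `COc1cc2c(cc1OC)C(c1ccccc1)=NN=C(S)C2` differs from compound 1 in one place: hydrogen in place of amino on an aromatic carbon. Among the measured compounds shown here, no measured pair shows this change, so its size is open. The expectation is a modest step from compound 1 to compound 4 of a 1.6-fold higher number from compound 1 to compound 4 (0.20 log units; within the scatter), toward a higher number but not clearly beyond the scatter. Compound 4 is therefore estimated at 30 umol/kg, with a range from 12 umol/kg to 80 umol/kg.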

Compound 4, dose for half-maximal effect: 19.7 umol/kg
The estimate for compound 4 lay 1.5-fold (0.18 log units) above the measured number, and the stated range covers the measured number.
By their numbers in this assay, from the lowest: compounds 1, 4 and 3 (each within the scatter of the next). At a limit, above all of these: compound 2.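

Among the compounds shown here, the change from 3-aminophenyl to phenyl comes to a 1.0-fold higher number from compound 1 to compound 4 (0.02 log units; within the scatter) in this assay and gives the first reading for this position, since no earlier pair differed only here. Between compound 1 and compound 4, the amino group on this aromatic carbon therefore makes no difference beyond the scatter. No measurement shown bears on the cause of this result.

As far as these compounds go, it remains open whether a carboxylic acid or a dimethylamino group at this place would also stay within the scatter of compound 4.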